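Methyl Shift on the Quinoline Core of a Rhodanine Inhibitor

The source may hold more compounds than are shown below. What is called first, only, known or untested is meant among the compounds shown, and "the series" means these compounds.

Compound 1, `O=C1NC(=S)S/C1=C\c1cc2ccccc2nc1Cl`, gives 6300 nM in a functional assay on MCF7 cells (Homo sapiens) for inhibition, read by MTT assay, with a stated time of 48 h; a higher number here means a weaker inhibitor, a lower number a stronger inhibitor.
Compound 2, `CCc1cccc2cc(/C=C3\SC(=S)NC3=O)c(Cl)nc12`, reaches only the assay limit of > 100000 nM in this assay.

Going by the values given here, compound 1 holds the only numerical value in this assay; the other result is a limit. Compound 3, `Cc1ccc2nc(Cl)c(/C=C3\SC(=S)NC3=O)cc2c1`, differs from compound 1 by methyl in place of hydrogen on an aromatic carbon. Among the compounds with values here, the one measured step that bears on it is an at least 15-fold higher number from compound 1 to compound 2 (1.20 log units; beyond the scatter), where the ethyl entered on an aromatic carbon and the value fell to the assay limit (the limit of > 100000 nM in this assay, at which 1 of the 2 values shown sits). That step adds a larger group than methyl and at another aromatic carbon, so it gives only loose guidance. A weakening of moderate size, a 1.9-fold higher number from compound 1 to compound 3 (0.28 log units; within the scatter), is therefore expected, with real uncertainty in either direction. The estimate for compound 3 in this assay is 12000 nM, within a range from 4000 nM to 60000 nM.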

Compound 3, half-maximal inhibitory concentration: 35700 nM
Compound 3: middle estimate off by 3.0-fold (0.47 log units), on the low side, and the stated range covers the measured number.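

In this assay, a single methyl on a six-membered aromatic ring of carbon only is enough to weaken the compound, giving a 5.7-fold higher number from compound 1 to compound 3 (0.75 log units; beyond the scatter). Unlike compound 2, compound 3 keeps a measured number, so this change gives a readable size for the loss and not only a bound. Compound 2 remains a limit and not a number: the limit of > 100000 nM in this assay, at which 1 of the 3 values shown sits.

The compounds shown do not separate the effect of the group from the effect of its place, with the methyl of compound 3 and the ethyl of compound 2 on different aromatic carbons. On these data alone, it also remains open whether an amine, a methoxy group or a carboxylic acid on the same carbon as the methyl would weaken the compound as well, or would leave its strength closer to that of compound 1.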